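The compounds below may be only part of what the source reports. "The series", "measured", "known", "first", "only" and "open" are said of these compounds alone.

Three compounds have so far been taken through an ADME assay on CHO cells (Cricetulus griseus) for cytotoxicity, read by LDH release; on this read-out higher numbers stand for weaker inhibition and lower numbers for stronger inhibition. Compound 1 (`CC(Sc1ccc(Cl)cc1Cl)C(=O)NCc1ccc(F)cc1`) gives > 100000 nM, which is a limit of the assay and not a number. For compound 2 (`CC(C(=O)NCc1ccc(F)cc1)S(=O)(=O)c1ccc(Cl)cc1Cl`) the result reads "not determined" (no result reported). Compound 3 (`CC(Oc1ccc(Cl)cc1Cl)C(=O)NC(c1ccc(F)cc1)C(C)C`) gives > 100000 nM, again a limit and not a number. The picture so far is the limit of > 100000 nM in this assay, at which 2 of the 3 values shown sit, and compound 3 stands at that limit.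

Compound 4 (`COC(=O)C(NC(=O)C(C)Oc1ccc(Cl)cc1Cl)c1ccc(F)cc1`) carries methoxycarbonyl in place of isopropyl on a saturated chain carbon bound to an amide-type nitrogen and an aromatic carbon. For the measured compounds named here, no measured pair of compounds shows what a single change does in this assay, so no step beyond the scatter is expected, in either direction. The expected size of the change is a number no higher from compound 3 to compound 4 (the limit leaves the size open), and a further limit is the likeliest report. Compound 4 is estimated at 100000 nM, with an expected range from 50000 nM to 200000 nM.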

Compound 4, half-maximal inhibitory concentration: > 100000 nM
Compound 4 gave a limit, no number (the forecaster's own chance of this, stated with the estimate: 80%); the middle value lies on the limit itself.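

No step can be read between compound 3 and compound 4, since each gives only a limit and not a number in this assay, as the results show: the limit of > 100000 nM in this assay, at which 3 of the 4 values shown sit.

The compounds shown leave open whether any single change moves the read-out in this assay at all.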